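The source may report more compounds than this note shows. Statements on the series, on what has been measured and on what is new or still open speak of the compounds shown alone.

For the measured compounds named here, in a physicochemical assay for lipophilicity, using the shake flask method, in phosphate buffer, measured as octanol-water partition, with a stated time of 30 min, at pH 7.4 (a higher number here means a more lipophilic compound, a lower number a more polar compound), compound 1 `O=C1CCCN1c1cnc(NCc2c(F)ccc3c2CCO3)c2cn[nH]c(=O)c12` gives 1.8 while compound 2 `CNC(=O)c1ncc(-c2cnc(NCc3c(F)ccc4c3CCO4)c3cn[nH]c(=O)c23)n1C` gives 2.5 as the highest number so far. Compound 3 `CNC(=O)c1ccc(-c2cnc(NCc3c(F)ccc4c3CCO4)c3cn[nH]c(=O)c23)c(C)n1` differs from compound 2 in one group on an aromatic carbon: 2-methyl-6-(methylcarbamoyl)pyridin-3-yl in place of 1-methyl-2-(methylcarbamoyl)-1H-imidazol-5-yl on an aromatic carbon while the shared core stays the same. One five-membered aromatic ring gives way to one six-membered aromatic ring, and methylcarbamoyl is named in both the leaving and the entering group. Going by the values given here, only one measured step offers any guide, and it is an indirect one. That step is a number 0.70 log units higher from compound 1 to compound 2 (beyond the scatter) and it brought in the group that now leaves, replacing 2-oxopyrrolidin-1-yl. Among the compounds with values here, it was modest in size, but it was a different exchange, and no measured pair shows the new group directly. A small rise in this assay is therefore expected, smaller than that earlier step and possibly within the scatter. The estimated change is a number 0.20 log units higher from compound 2 to compound 3 (within the scatter) for this exchange. The estimate for compound 3 is 2.7 with an expected range from 2.2 to 3.2 in this measurement.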

Compound 3, distribution coefficient: 2.9
Estimate against measurement, compound 3: 0.20 log units below; low and high end bracket the measured number.
By their numbers in this assay, from the lowest: compound 1; then compound 2; then compound 3.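

In this assay the exchange of 1-methyl-2-(methylcarbamoyl)-1H-imidazol-5-yl for 2-methyl-6-(methylcarbamoyl)pyridin-3-yl gives a number 0.40 log units higher from compound 2 to compound 3 (beyond the scatter) and so shows that the number still moves when methylcarbamoyl is named in both the leaving and the entering group. Measured against 2-oxopyrrolidin-1-yl, the same entering group gives a number 1.10 log units higher from compound 1 to compound 3 (beyond the scatter) and places compound 3 highest of the three, with both of its steps beyond the scatter. The exchange changes the ring size, the hetero atoms in the ring and the heavy atom count all at once, and no evidence is available on which of these changes matters.

The compounds shown leave open how much of the rise belongs to the methyl group on the six-membered ring and how much to the ring itself. They also leave open how the number would respond if a carboxylic acid or an amine took the place of methylcarbamoyl on that ring.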